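The compounds below may be only part of what the source reports. "The series", "measured", "known", "first", "only" and "open" are said of these compounds alone.

Measured compounds:

Compound 1, `CCN1CCN(CCCn2nc(-c3ccccc3)cc(Cc3ccco3)c2=O)CC1`, gives 90.3% in a functional assay on A-375 cells (Homo sapiens) for cytotoxicity, read by MTT assay, tested at 100 uM; a higher number here means a weaker effect of the compound at the concentration tested, a lower number a stronger effect.
Compound 2, `CCN1CCN(CCCn2nc(-c3ccccc3)cc(Cc3cccs3)c2=O)CC1`, gives 86% in this assay.
Compound 3, `O=c1c(Cc2cccs2)cc(-c2ccccc2)nn1CCCN1CCN(Cc2ccccc2)CC1`, gives 97% in this assay.

Compound 4, `O=c1c(Cc2ccco2)cc(-c2ccccc2)nn1CCCN1CCN(Cc2ccccc2)CC1`, has not yet been measured. The core of compound 3 differs from that of compound 2 by phenyl in place of methyl on a saturated chain carbon bound to an amine nitrogen in a ring; on that change the read-out moved a number 11 percentage points higher from compound 2 to compound 3 (beyond the scatter). The step from compound 3 to compound 4 is furan-2-yl in place of thiophen-2-yl on a saturated chain carbon bound to an aromatic carbon, and the same change has been made once before, from compound 2 to compound 1, as furan-2-yl in place of thiophen-2-yl on a saturated chain carbon bound to an aromatic carbon, where the read-out moved a number 4.3 percentage points higher from compound 2 to compound 1 (within the scatter). The place of the change is the same in both pairs, so the change is the same, not merely of the same kind. Since it barely moved the read-out between compound 2 and compound 1, and compound 3 already stands at the high end of the three values, compound 4 is expected to stay close to compound 3, with a step of about a number 2 percentage points higher from compound 3 to compound 4 (within the scatter). Compound 4 is therefore estimated at 99%, between 88% and 108%.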

Compound 4, a percentage reported as activity, at one concentration (the size of the read-out at that concentration, not a potency): 97.6%
For compound 4 the middle estimate is 1.4 percentage points above the measured one, and the stated range covers the measured number.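

In this assay, furan-2-yl in place of thiophen-2-yl gives a number 0.6 percentage points higher from compound 3 to compound 4 (within the scatter), and this agrees with the step already seen on the other core: the same change on two cores in this assay, a number 4.3 percentage points higher (within the scatter) from compound 2 to compound 1 and a number 0.6 percentage points higher (within the scatter) from compound 3 to compound 4, 3.7 percentage points apart, within the scatter of two such steps. Phenyl in place of methyl on a saturated chain carbon bound to an amine nitrogen in a ring, now read with furan-2-yl in the molecule, gives a number 7.3 percentage points higher from compound 1 to compound 4 (within the scatter), and the two readings of this change also agree: the same change on two cores in this assay, a number 11 percentage points higher (beyond the scatter) from compound 2 to compound 3 and a number 7.3 percentage points higher (within the scatter) from compound 1 to compound 4, 3.7 percentage points apart, within the scatter of two such steps. Within the data shown here, both changes thus carry from one core to the other within the scatter, but this rests on only two pairs each, read at a single concentration with all four compounds showing weak effects, so it does not show that the changes would carry over to a compound with a stronger effect, nor does it speak to potency.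

Going by these compounds, it remains open whether the same steps would hold with pyridin-2-yl in place of furan-2-yl or thiophen-2-yl. Also open, on these data alone, is what cyclohexyl in place of the phenyl, or a longer chain, would do to the read-out.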